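A second bromo on compound 1: working notes

The source may report more compounds than this note shows. Statements on the series, on what has been measured and on what is new or still open speak of the compounds shown alone.

Values in a functional assay on Caco-2 cells (Homo sapiens) for inhibition, read by MTT assay, with a stated time of 48 h (on this read-out higher numbers stand for weaker inhibition and lower numbers for stronger inhibition), for the three measured compounds:
compound 1 `COc1cc(/C=N/Nc2nc(-c3ccc(Br)cc3)cs2)cc(Br)c1OC`: 36200 nM
compound 2 `COc1ccccc1-c1csc(N/N=C/c2cc(Br)c(OC)c(OC)c2)n1`: > 100000 nM, a limit of the assay and not a number
compound 3 `COc1cc(/C=N/Nc2nc(-c3cccc(Br)c3)cs2)cc(Br)c1OC`: 43400 nM

Compound 1 gives the lowest of the two numbers in this assay. Compound 3 is nearest, and the step of a 1.2-fold higher number from compound 1 to compound 3 (0.08 log units; within the scatter) lies within the scatter, so no order between the two is claimed. The third value is a limit (the limit of > 100000 nM in this assay, at which 1 of the 3 values shown sits). The step of an at least 2.7-fold higher number from compound 1 to compound 2 (0.44 log units; beyond the scatter) is beyond the scatter, as is the step of an at least 2.3-fold lower number from compound 2 to compound 3 (0.36 log units; beyond the scatter).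

Compound 4 `COc1cc(/C=N/Nc2nc(-c3ccc(Br)cc3)cs2)c(Br)c(Br)c1OC` differs from compound 1 at one place: bromo in place of hydrogen on an aromatic carbon. All three measured steps vary the aryl group at the other end of the shared core; none changes the ring that receives the new bromo, so none bears directly on this step. For the measured compounds named here, the nearest precedent is that moving the bromo within that other aryl group in a 1.2-fold higher number from compound 1 to compound 3 (0.08 log units; within the scatter) stayed within the scatter, while exchanging it for methoxy in an at least 2.7-fold higher number from compound 1 to compound 2 (0.44 log units; beyond the scatter) went beyond it. Going by the values given here, with no direct analogue, no step beyond the scatter is expected in either direction. Compound 4 is therefore estimated at 32000 nM, within 12000 nM to 85000 nM, which corresponds to an expected step of a 1.1-fold lower number from compound 1 to compound 4 (0.05 log units; within the scatter).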

Compound 4, half-maximal inhibitory concentration: > 100000 nM
Compound 4: no number, only a limit; the forecaster's own chance of this, stated with the estimate: 15%; at least 3.1-fold (0.49 log units) between middle value and limit.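

In this assay, for the compounds shown here, the step of an at least 2.7-fold higher number from compound 1 to compound 4 (0.44 log units; beyond the scatter) is the first measured change on the ring that carries the two methoxy groups, and it lies beyond the scatter, towards weaker inhibition. Compound 4 gives > 100000 nM as a limit of the assay and not a number, so the direction of the step is fixed but its full size is not. The earlier steps showed sensitivity only in the aryl group at the other end of the shared core, whereas this one shows that the aromatic carbon ortho to a bromo group and para to a methoxy group does not accept a bromo in place of hydrogen without a weaker read-out, and more of the compounds shown now sit at the same limit: the limit of > 100000 nM in this assay, at which 2 of the 4 values shown sit.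

Hydrogen and bromo are the only groups shown at this position, so it remains open whether the weaker read-out is specific to bromo or would also follow from a fluoro, a methyl, a hydroxy or an amine on the same carbon. Going by these compounds, it also remains open whether the same bromo would have a comparable effect on compound 3, which carries the 3-bromophenyl group.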